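Ethyl in Place of Trifluoromethyl on an Aromatic Ether

The source may hold more compounds than are shown below. What is called first, only, known or untested is meant among the compounds shown, and "the series" means these compounds.

Measured so far in a functional assay on PC-3 cells (Homo sapiens) for antiproliferative activity, read by MTT assay, with a stated time of 48 h; on this read-out lower numbers stand for stronger inhibition and higher numbers for weaker inhibition:
Compound 1 `CCn1c(C(=O)NCCCN(C)C)ccc1C(CC)(CC)c1ccc(OCCC(O)(CC)CC)c(C)c1` gives 2150 nM 
Compound 2 `CCn1c(C(=O)NCC#N)ccc1C(CC)(CC)c1ccc(OCCC(O)(CC)CC)c(C)c1` gives 17800 nM 
Compound 3 `CCn1c(C(=O)Nc2ccc(OC(F)(F)F)cc2)ccc1C(CC)(CC)c1ccc(OCCC(O)(CC)CC)c(C)c1` gives > 50000 nM as a limit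

Compound 3 has no exact number: it stands at the limit of > 50000 nM in this assay, at which 1 of the 3 values shown sits. Compound 4 `CCOc1ccc(NC(=O)c2ccc(C(CC)(CC)c3ccc(OCCC(O)(CC)CC)c(C)c3)n2CC)cc1` differs from it by ethyl in place of trifluoromethyl on an oxygen on an aromatic ring. For the measured compounds named here, no measured step makes this exchange. Going by the values given here, two steps bear on it only indirectly, both placing 4-(trifluoromethoxy)phenyl on the amide-type nitrogen: an at least 23-fold higher number from compound 1 to compound 3 (1.36 log units; beyond the scatter), which is large, and an at least 2.8-fold higher number from compound 2 to compound 3 (0.44 log units; beyond the scatter), which is at least modest. With 4-ethoxyphenyl on that same nitrogen, compound 4 is expected to remain much weaker than compound 1 at 2150 nM in this assay. No step beyond the scatter is therefore expected, and another limit is quite possible. The expected change is an at least 1.1-fold lower number from compound 3 to compound 4 (0.04 log units; that floor lies within the scatter) overall. Compound 4 is estimated at 45000 nM, with an expected range of 18000 nM to 100000 nM.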

Compound 4, half-maximal inhibitory concentration: > 50000 nM
Compound 4: a limit, no number; the forecaster's own chance of this, stated with the estimate: 55%; at least 1.1-fold (0.04 log units) between middle value and limit.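

In this assay compound 4 gives > 50000 nM, which is a limit and not a number. Compound 3 is also a limit, so the step between these two cannot be read, and the exchange of trifluoromethyl for ethyl on this oxygen has no measurable size here: the limit of > 50000 nM in this assay, at which 2 of the 4 values shown sit.

What the result adds is that the loss seen with 4-(trifluoromethoxy)phenyl on the amide-type nitrogen is not confined to that group, since 4-ethoxyphenyl there also gives an at least 2.8-fold higher number from compound 2 to compound 4 (0.44 log units; beyond the scatter) and an at least 23-fold higher number from compound 1 to compound 4 (1.36 log units; beyond the scatter).

As far as these compounds go, how far compound 3 and compound 4 lie past the limit, and so whether they differ at all, remains open. Also open, from the compounds shown here alone, is whether an amine or a carboxylic acid in place of ethoxy on the phenyl ring would bring a value back within the range of the assay.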